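From bromo to acetoxy on the aromatic ring

The source may hold more compounds than are shown below. What is called first, only, known or untested is meant among the compounds shown, and "the series" means these compounds.

In a functional assay on Bel-7402 cells (Homo sapiens) for cytotoxicity, read by MTT assay, with a stated time of 72 h (a lower number here means a stronger inhibitor, a higher number a weaker inhibitor), compound 1 `Cc1ccc(/C=C/C=C2\CCC=CC2=O)cc1` gives 6300 nM, compound 2 `O=C1C=CCC/C1=C\C=C\c1ccc(F)cc1` gives 1800 nM and compound 3 `O=C1C=CCC/C1=C\C=C\c1ccc(Br)cc1` gives 3600 nM. Compound 3 stands within the scatter of the other two. The measured steps leading to it are a 1.8-fold lower number from compound 1 to compound 3 (0.24 log units; within the scatter) and a 2.0-fold higher number from compound 2 to compound 3 (0.30 log units; within the scatter). Compound 4 `CC(=O)Oc1ccc(/C=C/C=C2\CCC=CC2=O)cc1` carries acetoxy in place of bromo on an aromatic carbon. All the measured changes fall at this same place, and the largest is a 3.5-fold lower number from compound 1 to compound 2 (0.54 log units; beyond the scatter). None of them involves acetoxy, so they offer only a loose guide. A step beyond the scatter is therefore not expected in this assay. The expected change is a 1.2-fold lower number from compound 3 to compound 4 (0.08 log units; within the scatter). Compound 4 is estimated at 3000 nM, with a range from 1200 nM to 8000 nM.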

Compound 4, half-maximal inhibitory concentration: 3800 nM
Estimate against measurement, compound 4: 1.3-fold (0.10 log units) below, within the range that was stated.
By their numbers in this assay, from the lowest: compounds 2, 3, 4 and 1 (each within the scatter of the next, the first and the last beyond it).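

In this assay, acetoxy, with more heavy atoms and more hydrogen-bond acceptors than bromo, reads the same as bromo at this position (a 1.1-fold higher number from compound 3 to compound 4 (0.02 log units; within the scatter)). Against methyl the result also stays within the scatter (a 1.7-fold lower number from compound 1 to compound 4 (0.22 log units; within the scatter)), and only the comparison with fluoro goes beyond it, modestly (a 2.1-fold higher number from compound 2 to compound 4 (0.32 log units; beyond the scatter)). No measurement here gives a reason for these numbers.

Still open, going by these compounds, is how an amine or a carboxylic acid would fare on this aromatic carbon. The compounds shown also leave open whether a longer ester chain would read like acetoxy.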